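Nitro for fluoro on the pendant aryl of compound 3

The compounds below may be only part of what the source reports. "The series", "measured", "known", "first", "only" and "open" are said of these compounds alone.

Measured compounds:
compound 1 `Cc1ccc(-c2ccc([N+](=O)[O-])cc2)n1-c1ccc(-c2nc3ccccc3s2)cc1`: 3900 nM
compound 2 `COc1ccc2nc(-c3ccc(-n4c(C)ccc4-c4ccc(C)cc4)cc3)sc2c1`: 4010 nM
compound 3 `COc1ccc2nc(-c3ccc(-n4c(C)ccc4-c4ccc(F)cc4)cc3)sc2c1`: 4060 nM

In a functional assay on MDA-MB-231 cells (Homo sapiens) for cytotoxicity, read by sulforhodamine B assay, with a stated time of 48 h (a higher number here means a weaker inhibitor of growth, a lower number a stronger inhibitor of growth), compound 3 gives the highest of the three numbers, yet its gaps to compound 2 and to compound 1 both lie within the scatter, so no order among them can be claimed. The step to compound 4 `COc1ccc2nc(-c3ccc(-n4c(C)ccc4-c4ccc([N+](=O)[O-])cc4)cc3)sc2c1` is nitro in place of fluoro on an aromatic carbon. Within the data shown here, one measured step bears on it: a 1.0-fold higher number from compound 2 to compound 3 (0.01 log units; within the scatter), an exchange of groups on the same aromatic carbon that changed nothing beyond the scatter. Compound 1, which carries a nitro group on a pendant aryl without the methoxy of the shared core, gives a number close to compounds 2 and 3. Compound 4 is therefore expected to show a 1.0-fold lower number from compound 3 to compound 4 (0.01 log units; within the scatter), no shift beyond the scatter, with an estimate of 4000 nM ranging from 2000 nM to 8000 nM.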

Compound 4, concentration for 50% growth inhibition: 4560 nM
Compound 4: middle estimate off by 1.1-fold (0.06 log units), on the low side, within the range that was stated.
By their numbers in this assay, from the lowest: compounds 1, 2, 3 and 4 (each within the scatter of the next).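

In this assay the change from 4-fluorophenyl to 4-nitrophenyl gives a 1.1-fold higher number from compound 3 to compound 4 (0.05 log units; within the scatter) and nitro in place of methyl gives a 1.1-fold higher number from compound 2 to compound 4 (0.06 log units; within the scatter) so this aromatic carbon, para to a large group, has now carried methyl, fluoro and nitro with no shift beyond the scatter. With nitro held in place, methoxy in place of hydrogen on the core gives a 1.2-fold higher number from compound 1 to compound 4 (0.07 log units; within the scatter) and so also stays within the scatter. No evidence is available to explain these results. From the compounds shown here alone, whether an amine or a carboxylic acid on this carbon would move the number beyond the scatter remains open.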